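Swapping the Aryl Group on a Sulfonyl Sulfur

The source may report more compounds than this note shows. Statements on the series, on what has been measured and on what is new or still open speak of the compounds shown alone.

In a functional assay on K562 cells (Homo sapiens) for cytotoxicity, read by MTT assay, with a stated time of 3 days (a lower number here means a stronger inhibitor, a higher number a weaker inhibitor), compound 1 (`N#Cc1c(-c2ccccc2)nc(SCc2nc3ccccc3[nH]2)nc1N1CCNCC1`) gives 4.38 nM and compound 2 (`CN1CCN(c2nc(SCc3nc4ccccc4[nH]3)nc(-c3ccccc3)c2C#N)CC1`) gives 2.4 nM, with a 1.8-fold lower number from compound 1 to compound 2 (0.26 log units; within the scatter). Compound 3 (`Cc1ccc(S(=O)(=O)N2CCN(c3nc(SCc4nc5ccccc5[nH]4)nc(-c4ccccc4)c3C#N)CC2)cc1`) gives 11.3 nM, the highest number of the three. Compound 4 (`N#Cc1c(-c2ccccc2)nc(SCc2nc3ccccc3[nH]2)nc1N1CCN(S(=O)(=O)c2ccccc2[N+](=O)[O-])CC1`) differs from it in one place, with 2-nitrophenyl in place of 4-methylphenyl on a sulfonyl sulfur. Going by the values given here, no measured step changes this group directly. The closest guides are the modest steps that bring in the whole sulfonyl group, a 2.6-fold higher number from compound 1 to compound 3 (0.41 log units; beyond the scatter) and a 4.7-fold higher number from compound 2 to compound 3 (0.67 log units; beyond the scatter). A smaller change seems likely for a swap within that group, so the expected outcome in this assay is a 1.1-fold lower number from compound 3 to compound 4 (0.05 log units; within the scatter), with no firm direction. Compound 4 is estimated at 10 nM, with an expected range from 3.5 nM to 30 nM.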

Compound 4, half-maximal inhibitory concentration: 14.7 nM
Compound 4: middle estimate off by 1.5-fold (0.17 log units), on the low side, within the range that was stated.
By their numbers in this assay, from the lowest: compounds 2 and 1 (each within the scatter of the next); then compounds 3 and 4 (each within the scatter of the next).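

In this assay, changing the aryl group on the sulfonyl sulfur gives a 1.3-fold higher number from compound 3 to compound 4 (0.11 log units; within the scatter), so these two aryl groups cannot be told apart here. The sulfonyl step also holds with this second aryl group: a 3.4-fold higher number from compound 1 to compound 4 (0.53 log units; beyond the scatter) and a 6.1-fold higher number from compound 2 to compound 4 (0.79 log units; beyond the scatter). No measurement shown accounts for these results. The compounds shown leave open whether the higher numbers come from the sulfonyl group or from its aryl ring. A methylsulfonyl or acetyl group on the same ring nitrogen would help separate the two.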